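This account rests on a few compounds, and the source may have more. Where it says the series, first, only, none or still open, it means among the compounds named here.

In a functional assay on DU-145 cells (Homo sapiens) for cytotoxicity, read by MTT assay, with a stated time of 72 h (on this read-out higher numbers stand for weaker inhibition and lower numbers for stronger inhibition), compound 1 (`CC(C)NC(=S)N/N=C1\CC(c2ccc(O)cc2)Oc2cc(O)ccc21`) gives 60400 nM and compound 2 (`Oc1ccc(C2C/C(=N\NC(=S)N3CCOCC3)c3ccc(O)cc3O2)cc1`) gives 84500 nM so the two lie within the scatter of each other. Going on to compound 3 (`CC(C)(C)NC(=S)N/N=C1\CC(c2ccc(O)cc2)Oc2cc(O)ccc21`) the change is (tert-butyl)amino in place of morpholin-4-yl on a thiocarbonyl carbon on the thiocarbonyl carbon. Going by the values given here, the one measured step bearing on it is a 1.4-fold higher number from compound 1 to compound 2 (0.15 log units; within the scatter) at that same carbon, so no step beyond the scatter is expected in this assay for this change. The estimated move is a 1.4-fold lower number from compound 2 to compound 3 (0.15 log units; within the scatter) and nothing larger is expected. Compound 3 is expected at 60000 nM with an estimated range of 28000 nM to 120000 nM in this series.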

Compound 3, half-maximal inhibitory concentration: 42900 nM
Compound 3: the middle estimate sits 1.4-fold (0.15 log units) above what was measured, within the range that was stated.
By their numbers in this assay, from the lowest: compounds 3, 1 and 2 (each within the scatter of the next).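

In this assay (tert-butyl)amino in place of morpholin-4-yl on the thiocarbonyl carbon gives a 2.0-fold lower number from compound 2 to compound 3 (0.29 log units; within the scatter) and stays within the scatter, although a ring without a hydrogen-bond donor leaves and a ringless group with one enters. Methyl in place of hydrogen on the saturated chain carbon gives a 1.4-fold lower number from compound 1 to compound 3 (0.15 log units; within the scatter) and also stays within the scatter. No supporting data bear on why these groups read alike.

From the compounds shown here alone, whether a phenyl group, a carboxylic acid or a longer chain ending in an amine on the thiocarbonyl carbon would move the number beyond the scatter remains open.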